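This account rests on a few compounds, and the source may have more. Where it says the series, first, only, none or still open, it means among the compounds named here.

Measured so far in an ADME assay on microsomes from liver (Homo sapiens) for metabolic stability, using NADPH, with a stated time of 40 min, tested at 2 uM; on this read-out higher numbers stand for a longer-lived compound and lower numbers for a shorter-lived compound

Compound 1 (`Fc1cc2c(-c3ccc4c(C(F)(F)F)cccc4n3)c[nH]c2c(F)c1F`) gives 1.12 h
Compound 2 (`Fc1cc(Cl)cc2c(-c3ccc4ccccc4n3)c[nH]c12`) gives 0.633 h
Compound 3 (`Cc1cccc2c(-c3ccc4ccc(Cl)cc4n3)c[nH]c12`) gives 1.48 h

Compound 1 holds the middle place among these three numbers, and its value lies within the scatter of both other compounds. The unmeasured compound 4 (`Fc1cc2c(-c3ccc4ccccc4n3)c[nH]c2c(F)c1F`) keeps the core of compound 1 and carries hydrogen in place of trifluoromethyl on an aromatic carbon. The change falls on a six-membered aromatic ring of carbon only, part of a fused or bridged system of two rings.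

Among the compounds with values here, no pair of measured compounds isolates this change, so the data give no direct size for it. Neither compound 2 (0.633 h) nor compound 3 (1.48 h) carries trifluoromethyl, yet each lies within the scatter of compound 1 (1.12 h) on these numbers. Losing the group is therefore not expected to move the half-life far. The expected step (a 1.2-fold lower number from compound 1 to compound 4 (0.09 log units; within the scatter)) stays within the scatter, leaning only slightly toward a shorter-lived compound. Compound 4 is therefore estimated at 0.9 h with an expected range from 0.45 h to 1.8 h for its half-life in this assay when it is measured.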

Compound 4, half-life: 0.25 h
For compound 4 the middle estimate is 3.6-fold (0.56 log units) above the measured one; the whole stated range lies above it.
By their numbers in this assay, from the lowest: compound 4; then compounds 2, 1 and 3 (each within the scatter of the next, the first and the last beyond it).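

Swapping trifluoromethyl for hydrogen on this aromatic carbon gives the first isolated reading of this position: in this assay, the half-life falls by a 4.5-fold lower number from compound 1 to compound 4 (0.65 log units; beyond the scatter). Within the data shown here, compounds 1 and 4 differ only at this carbon, so the whole step goes with this one change, while the earlier compounds differ from compound 1 in more than one place and could give no size for it. The result therefore makes this position one where the choice between trifluoromethyl and hydrogen clearly separates two otherwise identical compounds, but no measurement shown here gives a reason for the shift.

The compounds shown leave open whether a methoxy group or a nitrile on this same aromatic carbon would keep a half-life closer to that of compound 1 or of compound 4. They also leave open whether the same exchange would produce a step of similar size on the core of compound 2 or compound 3, where the other groups differ.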